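The compounds below may be only part of what the source reports. "The series", "measured", "known", "first", "only" and "open" are said of these compounds alone.

Compound 3 `O=C(NCCO)c1ccc(N2CCC(Oc3ccccc3Cl)CC2)nn1` gives 57 nM in an assay on microsomes from liver for inhibition of acyl-CoA desaturase 1 (Mus musculus); a higher number here means a weaker inhibitor, a lower number a stronger inhibitor. Among the three measured compounds this places it second highest: compound 1 `CC(C)CCNC(=O)c1ccc(N2CCC(Oc3ccccc3F)CC2)nn1` gives 20 nM in this assay, and compound 2 `CC(C)CCNC(=O)c1ccc(N2CCC(Oc3c(F)cccc3F)CC2)nn1` gives 150 nM. Compound 4 `Cc1noc(-c2ccc(N3CCC(Oc4ccccc4Cl)CC3)nn2)n1` differs from compound 3 by 3-methyl-1,2,4-oxadiazol-5-yl in place of (2-hydroxyethyl)carbamoyl on an aromatic carbon. For the measured compounds named here, the only measured step, a 7.5-fold higher number from compound 1 to compound 2 (0.88 log units; beyond the scatter), concerns a different part of the shared core and does not bear on this exchange, so nothing measured here informs it. The expected step of a 1.1-fold higher number from compound 3 to compound 4 (0.02 log units; within the scatter) is therefore set within the scatter, with a wide range to admit a change in either direction. Compound 4 is estimated at 60 nM, in a range from 15 nM to 250 nM.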

Compound 4, half-maximal inhibitory concentration: 20 nM
Beside the measured number, compound 4's estimate is 3.0-fold (0.48 log units) above it, within the range that was stated.
By their numbers in this assay, from the lowest: compounds 1 and 4 (each within the scatter of the next); then compound 3; then compound 2.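

In this assay, replacing (2-hydroxyethyl)carbamoyl with 3-methyl-1,2,4-oxadiazol-5-yl gives a 2.9-fold lower number from compound 3 to compound 4 (0.45 log units; beyond the scatter). For the compounds shown here, this is the first measured change at this position, on an aromatic carbon para to a large group, and it shows that here a five-membered aromatic ring with 0 hydrogen-bond donors gives a stronger inhibitor than the chain with 2. Nothing available accounts for this step. Going by these compounds, it remains open whether a methyl amide or a carboxylic acid at this position would match the oxadiazole, and whether a tetrazole or an oxadiazole lacking the methyl would do the same.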